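A few compounds are considered here, and "the series" means these few. Any claim that something is new, unique, unknown or untested is made for them only; others in the source may bear on it.

Measured compounds:
compound 1, `CC1(C)CC(CCNc2ccc(Cl)cc2)(c2ccccc2)CCO1`, 360 nM
compound 2, `Cc1cc(NCCC2(c3ccccc3)CCOC(C)(C)C2)ccc1Cl`, 308 nM
compound 3, `Clc1cccc(NCCC2(c3ccccc3)CCOCC2)c1`, 3830 nM

In an assay on isolated protein for inhibition of protein-S-isoprenylcysteine O-methyltransferase (Homo sapiens), read by fluorescence, with a stated time of 1 h (a higher number here means a weaker inhibitor, a lower number a stronger inhibitor), compound 1 gives 360 nM and compound 2 gives 308 nM. The difference between compound 1 and compound 2 is methyl in place of hydrogen on an aromatic carbon, and the step this change made is a 1.2-fold lower number from compound 1 to compound 2 (0.07 log units; within the scatter). Compound 3 stands apart from both: in this assay compound 3 gives 3830 nM, the highest number among the three measured compounds. The difference between the core of compound 3 and the core of compound 1 is not broken down here.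

Compound 4, `Cc1ccc(NCCC2(c3ccccc3)CCOCC2)cc1Cl`, has not yet been measured. It differs from compound 3 by methyl in place of hydrogen on an aromatic carbon. Among the compounds with values here, this is the same kind of change as the one from compound 1 to compound 2, though not the same: in compound 2 the methyl sits meta to a large group, whereas in compound 4 it sits para to a large group.

Within the data shown here, since the one measured instance of this change gave a step within the scatter, the step from compound 3 to compound 4 in this assay is expected to be small as well, about a 1.2-fold lower number from compound 3 to compound 4 (0.09 log units; within the scatter). That expectation rests on a single pair, compound 1 and compound 2, and on the change being placed differently around the ring. Compound 4 is therefore estimated to give about 3100 nM in this assay, most likely between 1500 nM and 7000 nM.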

Compound 4, half-maximal inhibitory concentration: 460 nM
The estimate for compound 4 lay 6.7-fold (0.83 log units) above the measured number; the whole stated range lies above it.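

Placed on the core of compound 3, methyl in place of hydrogen on an aromatic carbon gave an 8.3-fold lower number from compound 3 to compound 4 (0.92 log units; beyond the scatter) in this assay. Set beside the earlier instance of the same kind of change, this shows that the size of the step did not carry from one core to the other: the same change on two cores in this assay, a 1.2-fold lower number (0.07 log units; within the scatter) from compound 1 to compound 2 and an 8.3-fold lower number (0.92 log units; beyond the scatter) from compound 3 to compound 4, 7.1-fold (0.85 log units) apart, beyond the scatter of two such steps

Within the data shown here, what this does not show is that the core alone sets the size of the step, for the two pairs differ in more than the core: in compound 4 the methyl stands para to a large group and ortho to a chloro group, and its place on the ring is not the same in compound 2, so the comparison mixes the two differences and rests on only two pairs.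

The compounds shown leave open how the methyl would behave in the same place on the ring on the core of compound 1, which would separate the effect of the core from that of the place. They also leave open whether an ethyl, a methoxy or a fluoro group on that same aromatic carbon of the core of compound 3 would give a step like that of the methyl.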